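This account rests on a few compounds, and the source may have more. Where it says the series, first, only, none or still open, it means among the compounds named here.

The measured compounds:
Compound 1, `COc1cccc(CCC(=O)Nc2nc3ccccc3c(=O)s2)c1`, gives 173 nM in an assay on CHO cells for displacement of a labelled ligand from adenosine receptor A3 (Homo sapiens), read by scintillation counting, with a stated time of 60 min; on this read-out higher numbers stand for weaker inhibition and lower numbers for stronger inhibition.
Compound 2, `Cc1sc2nc(NC(=O)CCCc3ccccc3)sc(=O)c2c1C`, gives > 1000 nM in this assay, which is a limit of the assay and not a number.
Compound 3, `COc1cccc(/C=C/C(=O)Nc2nc3ccccc3c(=O)s2)c1`, gives > 1000 nM in this assay, again a limit of the assay rather than a number.

For the measured compounds named here, compound 1 therefore holds the only actual number here; the two other results sit at the edge of what the assay can report, as summed up by the limit of > 1000 nM in this assay, at which 2 of the 3 values shown sit. Compound 4, `O=C(CCCc1ccccc1)Nc1nc2ccccc2c(=O)s1`, has not yet been measured in this assay. It differs from compound 1 in one place: benzyl in place of 3-methoxyphenyl on a saturated chain carbon, two bonds along the chain from a carbonyl carbon. Going by the values given here, no step between measured compounds guides this change. Compound 2 carries a chain of the same shape on a different core, and its result is a limit, so it shows no more than that. A modest weakening is expected, a step of a 2.3-fold higher number from compound 1 to compound 4 (0.36 log units; beyond the scatter). Compound 4 is estimated at 400 nM, within 120 nM to 1500 nM, with a fair chance that the assay returns only a limit.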

Compound 4, inhibition constant: > 1000 nM
Compound 4: only a limit was reported; the forecaster's own chance of this, stated with the estimate: 30%; middle value at least 2.5-fold (0.39 log units) from the limit.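

Compound 4 gives > 1000 nM in this assay, which is a limit of the assay and not a number. For the compounds shown here, it still allows the first comparison in one place on the shared core: the step is an at least 5.7-fold higher number from compound 1 to compound 4 (0.76 log units; beyond the scatter) for benzyl in place of 3-methoxyphenyl, so the group at this place on the saturated chain clearly matters for binding. Going by these compounds alone, compound 1 remains the only compound with an actual number: the limit of > 1000 nM in this assay, at which 3 of the 4 values shown sit.

As far as these compounds go, how much weaker compound 4 really is stays unknown, and this single swap removes the methoxy oxygen while also changing the group that joins the ring to the chain, so the two changes cannot be told apart. A 3-methoxybenzyl group, a plain phenyl group or a 3-hydroxyphenyl group at this place would be needed to separate them.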